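The compounds below may be only part of what the source reports. "The series", "measured", "known", "first", "only" and "open" are said of these compounds alone.

Compound 2 `Cc1ccc2ncc(S(=O)(=O)c3ccc(C)c(C)c3)c(N3CCC(C)CC3)c2c1` was tested in an assay on isolated protein for displacement of a labelled ligand from metabotropic glutamate receptor 5 (Homo sapiens), with a stated time of 60 min, tested at 1 uM (a lower number here means less inhibition, a higher number more inhibition at the concentration tested (going by the name of the read-out)), and gives 90%. Its nearest measured neighbour is compound 1 `Cc1ccc2ncc(S(=O)(=O)c3ccc(F)cc3)c(N3CCC(C)CC3)c2c1`, which in this assay gives 90%, so the two stand level within the scatter, as the step of no change at the digits printed from compound 1 to compound 2 (within the scatter) shows. Compound 3 `Cc1ccc2ncc(S(=O)(=O)c3ccc(C#N)cc3)c(N3CCC(C)CC3)c2c1` is the next member of the series, differing from compound 2 only at the aryl group on the sulfonyl sulfur: 4-cyanophenyl in place of 3,4-dimethylphenyl on a sulfonyl sulfur. Going by the values given here, the one measured step that bears on this position, from a 4-fluorophenyl to a 3,4-dimethylphenyl, left the read-out level within the scatter; a nitrile has not yet been tried there, however. On that basis compound 3 is expected to stay close to compound 2, with a step of a number 5 percentage points lower from compound 2 to compound 3 (within the scatter) that is not expected to exceed the scatter. The estimate for compound 3 in this assay is 85%, with a range from 65% to 95%.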

Compound 3, a percentage reported as inhibition, at one concentration (the size of the read-out at that concentration, not a potency): 55%
Compound 3: middle estimate off by 30 percentage points, on the high side, and the stated range ends above it.
By their numbers in this assay, from the lowest: compound 3; then compounds 1 and 2 (each within the scatter of the next).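

The aryl group on the sulfonyl sulfur is not indifferent in this assay: where the earlier exchange left the read-out level, 4-cyanophenyl in place of 3,4-dimethylphenyl gives a number 35 percentage points lower from compound 2 to compound 3 (beyond the scatter). Cyano in place of fluoro on an aromatic carbon, a change at a single substituent, gives a number 35 percentage points lower from compound 1 to compound 3 (beyond the scatter), so the drop is seen against both earlier aryl groups, including one that carries no methyl groups. Nothing measured here accounts for this drop.

On these data alone, whether the drop is particular to the nitrile, or would also follow a methoxy, a trifluoromethyl or a primary amide on the same aryl ring, remains open. As far as these compounds go, it is also open whether the exchange would cost as much if the 4-methylpiperidine were replaced by a morpholine.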